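Oxygen-to-sulfur swap on the diamino core

The source may hold more compounds than are shown below. What is called first, only, known or untested is meant among the compounds shown, and "the series" means these compounds.

All numbers below come from a functional assay on OVCAR-4 cells (Homo sapiens) for inhibition, read by sulforhodamine B assay, with a stated time of 48 h; on this read-out lower numbers stand for stronger inhibition of growth and higher numbers for weaker inhibition of growth.

compound 1, `Nc1cc(N)c2nc(-c3ccccc3)c(Oc3ccc(Cl)c(Cl)c3)nc2c1`: 33100 nM
compound 2, `CCOC(=O)[C@H](CCC(=O)O)NC(=O)c1ccc(Sc2nc3cc(N)cc(N)c3nc2-c2ccccc2)cc1`: 16600 nM
compound 3, `CCOC(=O)[C@H](CCC(=O)O)NC(=O)c1ccc(Oc2nc3cc(N)cc(N)c3nc2-c2ccccc2)cc1`: 35500 nM

Compound 1 stands second highest of the three numbers. Its nearest neighbour is compound 3, and that gap lies within the scatter; its furthest is compound 2, and that gap also lies within the scatter. Among the compounds with values here, compounds 2 and 3 share the same acid-bearing side chain and differ only in the atom that joins it to the core; in this assay compound 2 gives 16600 nM and compound 3 gives 35500 nM, and no step has been computed for that pair.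

Compound 4, `Nc1cc(N)c2nc(-c3ccccc3)c(Sc3ccc(Cl)c(Cl)c3)nc2c1`, is not yet measured. It relates to compound 1 by (3,4-dichlorophenyl)sulfanyl in place of 3,4-dichlorophenoxy on an aromatic carbon. Within the data shown here, no measured pair with this exact change exists, so the expectation rests on compounds 2 and 3 as the only sulfur-versus-oxygen comparison available, which shows a modest lowering of the number with sulfur. The expected step from compound 1 to compound 4 is therefore small, toward a lower number, and may not exceed the scatter; the estimate corresponds to a 1.7-fold lower number from compound 1 to compound 4 (0.22 log units; within the scatter). For compound 4 the expected value in this assay is 20000 nM, with a range from 8000 nM to 50000 nM.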

Compound 4, concentration for 50% growth inhibition: 20000 nM
The estimate for compound 4 equals the measured number at the digits printed; measured number inside the range.
By their numbers in this assay, from the lowest: compounds 2, 4, 1 and 3 (each within the scatter of the next, the first and the last beyond it).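

In this assay, the exchange on the dichlorophenyl pair gives a 1.7-fold lower number from compound 1 to compound 4 (0.22 log units; within the scatter), so (3,4-dichlorophenyl)sulfanyl and 3,4-dichlorophenoxy on this aromatic carbon cannot be told apart on this read-out. This adds a second oxygen-to-sulfur comparison at this place, now with a group lacking the acid-bearing side chain: the same atom exchange separates compound 3 at 35500 nM from compound 2 at 16600 nM by more than the scatter, whereas the dichlorophenyl pair stays within it, so the two pairs do not establish a general effect of sulfur in this series. No measurement shown here bears on the reason for either result.

The compounds shown leave open whether any other linking atom at this carbon, such as an amine nitrogen or a methylene carbon, would give a step beyond the scatter from compound 1. They also leave open whether the dichlorophenyl group itself contributes to the values, which a plain phenyl group or a phenyl ring carrying a carboxylic acid in its place on the sulfur link of compound 4 could test.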